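This account rests on a few compounds, and the source may have more. Where it says the series, first, only, none or still open, it means among the compounds named here.

Measured compounds:
Compound 1 `Cc1cccc(-n2nncc2CN2C(=O)C3(C(C#N)=C(N)Oc4c(N)cc5nc6ccccc6nc5c43)c3ccccc32)c1`: in a functional assay on HCT-116 cells (Homo sapiens) for antiproliferative activity, read by MTT assay, with a stated time of 48 h (on this read-out lower numbers stand for stronger inhibition and higher numbers for weaker inhibition), compound 1 gives > 50000 nM, a limit of the assay.
Compound 2 `CCOc1ccccc1-n1nncc1CN1C(=O)C2(C(C#N)=C(N)Oc3c(N)cc4nc5ccccc5nc4c32)c2ccccc21`: in this assay compound 2 gives > 50000 nM, a limit of the assay.

Within the data shown here, compound 2 stands on no number of its own: its value in this assay is a limit, and the one other value is a limit as well. Both values sit at the limit of > 50000 nM in this assay, at which 2 of the 2 values shown sit. Among the measured compounds shown here, the only measured step, a step that the two limits leave unreadable from compound 1 to compound 2, runs between two limits, so its size and direction cannot be read.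

Compound 3 `N#CC1=C(N)Oc2c(N)cc3nc4ccccc4nc3c2C12C(=O)N(Cc1cnnn1-c1ccc([N+](=O)[O-])cc1[N+](=O)[O-])c1ccccc12` differs from compound 2 in one place: 2,4-dinitrophenyl in place of 2-ethoxyphenyl on an aromatic nitrogen. For the measured compounds named here, no measured step bears on this change. Going by the values given here, the single step available, from compound 1 to compound 2, is unreadable, so it offers no size to carry over, and the series gives no direction beyond the scatter to expect. In this assay the step is estimated as a number no higher from compound 2 to compound 3 (the limit leaves the size open), with wide uncertainty on either side.

Compound 3 is therefore expected in this assay at 50000 nM, within 10000 nM to 250000 nM, and most probably the assay will again report only a limit.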

Compound 3, half-maximal inhibitory concentration: 23900 nM
Beside the measured number, compound 3's estimate is 2.1-fold (0.32 log units) above it; low and high end bracket the measured number.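

Among these compounds, the aromatic nitrogen of the five-membered ring with 3 nitrogen now shows that the group on it can move the read-out: with 2,4-dinitrophenyl there, compound 3 gives 23900 nM in this assay, the only value that is a number and not a limit. The change gives an at least 2.0-fold lower number from compound 2 to compound 3 (0.32 log units; beyond the scatter), and against the 3-methylphenyl group it gives an at least 2.0-fold lower number from compound 1 to compound 3 (0.32 log units; beyond the scatter), so both replaced groups, one with a single methyl and one with an ethoxy, yield a readable step to the same 2,4-dinitrophenyl compound, whereas the step between those two groups themselves cannot be read. Both readable steps are minimum sizes, and their true size stays open, since the starting compounds carry only limits: the limit of > 50000 nM in this assay, at which 2 of the 3 values shown sit.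

Compound 3 alone does not tell whether both nitro groups are needed, or whether a phenyl ring carrying one nitro group would hold the same value. Nor do the compounds shown say whether other groups on this ring, such as trifluoromethyl, a carboxylic acid or an amine, would give a number rather than a limit.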